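A few compounds are considered here, and "the series" means these few. Any claim that something is new, unique, unknown or untested is made for them only; others in the source may bear on it.

Measured in an ADME assay on MT4 cells (Homo sapiens) for cytotoxicity, read by MTT assay, with a stated time of 4 days; on this read-out higher numbers stand for lower toxicity in this test and lower numbers for higher toxicity in this test:
- compound 1 `CC(=O)Nc1ccc2oc(-c3ccccc3)c(O)c(=O)c2c1`: 64700 nM
- compound 2 `COc1cccc(-c2oc3ccc(NC(C)=O)cc3c(=O)c2O)c1`: 33300 nM
- compound 3 `COc1ccc(-c2oc3ccc(NC(C)=O)cc3c(=O)c2O)cc1`: 98700 nM

Compound 3, at 98700 nM, stands clear of only one of the other two compounds. The measurements show a 3.0-fold higher number from compound 2 to compound 3 (0.47 log units; beyond the scatter), but also a 1.5-fold higher number from compound 1 to compound 3 (0.18 log units; within the scatter).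

Compound 4 `CC(=O)Nc1ccc2oc(-c3ccccc3F)c(O)c(=O)c2c1` has not yet been measured. Its structure departs from that of compound 3 as follows: 2-fluorophenyl in place of 4-methoxyphenyl on an aromatic carbon. The change is 2-fluorophenyl in place of 4-methoxyphenyl on an aromatic carbon, next to the ring oxygen and ortho to a hydroxy group.

For the measured compounds named here, none of the measured compounds carries fluorine, so no measured step tests this change directly. The closest evidence comes from the methoxy steps. Adding the group gave a 1.9-fold lower number from compound 1 to compound 2 (0.29 log units; within the scatter) and a 1.5-fold higher number from compound 1 to compound 3 (0.18 log units; within the scatter), and only moving it gave a modest step, a 3.0-fold higher number from compound 2 to compound 3 (0.47 log units; beyond the scatter). The methoxy group leaves in compound 4, and compound 1, which also lacks it, gives 64700 nM. A small downward drift is therefore expected, with no step beyond the scatter. The estimated change is a 1.6-fold lower number from compound 3 to compound 4 (0.22 log units; within the scatter). For compound 4 the expected value is 60000 nM, with an estimated range from 25000 nM to 130000 nM.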

Compound 4, half-maximal cytotoxic concentration: 171000 nM
Estimate against measurement, compound 4: 2.9-fold (0.45 log units) below; measured number above the stated range.
By their numbers in this assay, from the lowest: compounds 2, 1, 3 and 4 (each within the scatter of the next, the first and the last beyond it).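

In this assay, fluoro in place of hydrogen on the phenyl group, which sits on the aromatic carbon next to the ring oxygen, gives a 2.6-fold higher number from compound 1 to compound 4 (0.42 log units; beyond the scatter), whereas neither methoxy step from compound 1 left the scatter. The 2-fluorophenyl group thus gives the widest gap in this small set when set against 3-methoxyphenyl, a 5.1-fold higher number from compound 2 to compound 4 (0.71 log units; beyond the scatter), yet it cannot be separated from 4-methoxyphenyl, a 1.7-fold higher number from compound 3 to compound 4 (0.24 log units; within the scatter), so a substituent on this phenyl group can move the number towards lower toxicity in this test, though compound 3 and compound 4 do not differ beyond the scatter. No other measurement is at hand that would account for the fluoro step.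

The compounds shown leave open whether that step follows from fluoro as such or from its place on the phenyl group, as fluoro appears here only in 2-fluorophenyl. They also leave open how a chloro group, an amine or a carboxylic acid on that phenyl group would read in this assay, and whether any of them would go beyond the scatter from compound 1.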